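The compounds below may be only part of what the source reports. "The series", "measured", "known", "first", "only" and "open" are said of these compounds alone.

Measured so far:
- compound 1 `CCOC(=O)/C=C/C1=CC[C@H]2C(C)(C)CCC[C@]2(C)[C@H]1C=O`: 29000 nM
- compound 2 `COC(=O)/C=C/C=C/C1=CC[C@H]2C(C)(C)CCC[C@]2(C)[C@H]1C=O`: 25000 nM

In a functional assay on SK-MEL-28 cells (Homo sapiens) for inhibition, read by MTT assay, with a stated time of 72 h (a higher number here means a weaker inhibitor of growth, a lower number a stronger inhibitor of growth), compound 2 gives 25000 nM. Among the compounds with values here, the only measured step is a 1.2-fold lower number from compound 1 to compound 2 (0.06 log units; within the scatter), so the two numbers do not separate.

Next is compound 3 `C#CCCCOC(=O)/C=C/C1=CC[C@H]2C(C)(C)CCC[C@]2(C)[C@H]1C=O`. The change is ((pent-4-yn-1-yl)oxy)carbonyl in place of 2-(methoxycarbonyl)ethenyl on a double-bonded chain carbon bound to a double-bonded chain carbon.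

Within the data shown here, the one measured step at this place, a 1.2-fold lower number from compound 1 to compound 2 (0.06 log units; within the scatter), stayed within the scatter, and it is the only guide. Among the measured compounds shown here, no measured compound carries the pent-4-yn-1-yl chain, so the evidence is thin and the range is kept wide. No shift beyond the scatter is expected in this assay. The expected step is a 1.0-fold lower number from compound 2 to compound 3 (0.02 log units; within the scatter). For compound 3 the estimated value is 24000 nM, with an expected range of 11000 nM to 50000 nM.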

Compound 3, concentration for 50% growth inhibition: 36000 nM
Compound 3: the middle estimate sits 1.5-fold (0.18 log units) below what was measured, within the range that was stated.
By their numbers in this assay, from the lowest: compounds 2, 1 and 3 (each within the scatter of the next).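

In this assay, the longer group at this place does not separate from either earlier compound: the step is a 1.4-fold higher number from compound 2 to compound 3 (0.16 log units; within the scatter), and against the ethyl ester it is a 1.2-fold higher number from compound 1 to compound 3 (0.09 log units; within the scatter). Compounds 1, 2 and 3 therefore remain within the scatter of one another, now with ((pent-4-yn-1-yl)oxy)carbonyl, with its 8 heavy atoms and triple bond, added to the two groups seen earlier on a double-bonded chain carbon bound to a double-bonded chain carbon. No supporting data are available to interpret these small differences.

As far as these compounds go, whether a carboxylic acid or an amine at the end of this chain would give a step beyond the scatter remains open. The compounds shown also leave open whether any change elsewhere on the shared core would move the number further than these changes do.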